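A few compounds are considered here, and "the series" means these few. Any claim that something is new, unique, unknown or untested is made for them only; others in the source may bear on it.

Compound 3 `Cn1ccc2c(Oc3ccc(NC(=O)c4nn(-c5ccccc5)ccc4=O)cc3F)ccnc21` is the reference point for the step considered here. In a functional assay on HepG2 cells (Homo sapiens) for cytotoxicity, read by MTT assay, with a stated time of 72 h (on this read-out lower numbers stand for stronger inhibition and higher numbers for weaker inhibition), compound 3 gives > 60000 nM, which is a limit of the assay and not a number. Compound 2 `Cn1ccc2c(Oc3ccc(NC(=O)c4nn(-c5ccc(Br)cc5)ccc4=O)cc3F)ccnc21` carries bromo on the aromatic carbon where compound 3 carries hydrogen. In this assay compound 2 gives > 60000 nM, again a limit. The step that the two limits leave unreadable from compound 2 to compound 3 accordingly has no readable size. Compound 1 `Cn1ccc2c(Oc3ccc(NC(=O)c4nn(-c5ccc(Cl)c(F)c5)ccc4=O)cc3)ccnc21` shares with compound 4 the 4-chloro-3-fluorophenyl on the aromatic nitrogen and differs from compound 4 elsewhere in the shared core. In this assay compound 1 gives > 60000 nM, also a limit. The whole picture so far is the limit of > 60000 nM in this assay, at which 3 of the 3 values shown sit.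

Compound 4 `Cn1ccc2c(Oc3ccc(NC(=O)c4nn(-c5ccc(Cl)c(F)c5)ccc4=O)cc3F)ccnc21` is the next compound to be measured. The change from compound 3 is 4-chloro-3-fluorophenyl in place of phenyl on an aromatic nitrogen. No measured step bears a readable size on this change, since every value shown is a limit, and the step from compound 2 to compound 3 is unreadable for the same reason. The closest guide is compound 1, whose 4-chloro-3-fluorophenyl gives only > 60000 nM. Compound 4 is therefore expected to stay at the limit as well, with an estimated 60000 nM (range 30000 nM to 200000 nM), an expected step of a number no higher from compound 3 to compound 4 (the limit leaves the size open), not beyond the scatter.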

Compound 4, half-maximal inhibitory concentration: 22100 nM
The estimate for compound 4 lay 2.7-fold (0.43 log units) above the measured number; the whole stated range lies above it.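

In this assay, among these compounds, 4-chloro-3-fluorophenyl on the aromatic nitrogen gives the first steps with a readable lower bound: an at least 2.7-fold lower number from compound 3 to compound 4 (0.43 log units; beyond the scatter) against phenyl and an at least 2.7-fold lower number from compound 2 to compound 4 (0.43 log units; beyond the scatter) against 4-bromophenyl. The group does not do this alone, since compound 1 carries it as well, and fluoro in place of hydrogen on an aromatic carbon of the shared core gives an at least 2.7-fold lower number from compound 1 to compound 4 (0.43 log units; beyond the scatter). Compounds 2 and 3 carry that fluoro without the 4-chloro-3-fluorophenyl, so among the compounds shown a number appears only where the two changes meet, and everything else stays at the limit: the limit of > 60000 nM in this assay, at which 3 of the 4 values shown sit.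

From the compounds shown here alone, the full size of all three steps stays open, as one end of each is a limit, and the step between compound 2 and compound 3 cannot be read. Also open, going by these compounds, is whether the chloro or the fluoro of the 4-chloro-3-fluorophenyl carries the step, and how a phenyl bearing an amine or a carboxylic acid would read on the same aromatic nitrogen.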